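The source may hold more compounds than are shown below. What is called first, only, known or untested is meant among the compounds shown, and "the series" means these compounds.

Measured so far:
compound 1, `COc1cc2c(cc1N1C[C@@H](C)N[C@@H](C)C1)N(S(=O)(=O)Cc1cccc(I)c1)CC2` — in a functional assay for agonist activity at growth hormone secretagogue receptor type 1 (Homo sapiens), read by FLIPR (a higher number here means that more compound is needed for the effect, a lower number that less compound is needed), compound 1 gives 31.6 nM
compound 2, `COc1cc2c(cc1N1C[C@@H](C)N[C@@H](C)C1)N(S(=O)(=O)CCc1ccccc1Cl)CC2` — in this assay compound 2 gives 5.01 nM

Both compounds share the same core and differ only in the group attached to the sulfonyl sulfur. On the numbers shown, compound 2 stands at the lower end: the step of a 6.3-fold lower number from compound 1 to compound 2 (0.80 log units; beyond the scatter) is a modest one, beyond the usual scatter, so less of compound 2 is needed for the effect than of compound 1.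

Compound 3, `COc1cc2c(cc1N1C[C@@H](C)N[C@@H](C)C1)N(S(=O)(=O)c1ccc(-c3ccccn3)s1)CC2`, has not yet been tested. Its change from compound 2 is 5-(pyridin-2-yl)thiophen-2-yl in place of 2-(2-chlorophenyl)ethyl on a sulfonyl sulfur. Among the compounds with values here, this is a larger change than the one between compound 1 and compound 2: the saturated chain that linked the sulfonyl sulfur to the aromatic ring is gone, and an aromatic group with two rings is bound straight to the sulfur. Within the data shown here, the only measured step, a 6.3-fold lower number from compound 1 to compound 2 (0.80 log units; beyond the scatter), concerns a swap between two carbon-only aromatic groups on a chain and does not speak directly to this change, so the direction is uncertain. Compound 3 is therefore expected to land close to compound 2, with the step of a 3.0-fold higher number from compound 2 to compound 3 (0.48 log units; beyond the scatter) as the estimate. In this assay compound 3 is estimated at 15 nM, with a range from 2 nM to 120 nM.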

Compound 3, half-maximal effective concentration: 0.159 nM
Compound 3: middle estimate off by 94-fold (1.97 log units), on the high side; the whole stated range lies above it.
By their numbers in this assay, from the lowest: compound 3; then compound 2; then compound 1.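

At the sulfonyl sulfur, in this assay, the step of a 32-fold lower number from compound 2 to compound 3 (1.50 log units; beyond the scatter) shows that a saturated chain is not required for a low number: 5-(pyridin-2-yl)thiophen-2-yl, an aromatic group bound straight to the sulfur, does far better here than 2-(2-chlorophenyl)ethyl. Within the data shown here, the step of a 200-fold lower number from compound 1 to compound 3 (2.30 log units; beyond the scatter), with 3-iodobenzyl as the group that leaves, shows the same direction and reveals a much wider span at this one position than the first pair of compounds suggested. No measured evidence is available to explain this large drop.

The change replaces the chain, the chlorophenyl ring and the chlorine all at once, so the compounds shown cannot separate what each part of the new group contributes. On these data alone, it remains open whether a bare thiophen-2-yl, or a 5-phenylthiophen-2-yl carrying a carbon-only ring in place of the pyridine, would keep the number this low, and whether a methylene group inserted between the sulfur and the thiophene would preserve it.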